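Phenol for aniline on the benzylic arm of a shared core

The compounds below may be only part of what the source reports. "The series", "measured", "known", "first", "only" and "open" are said of these compounds alone.

Three compounds share the same core and differ only in the aromatic group carried on a saturated chain carbon bound to an aromatic nitrogen. Compound 1 `Cc1ccc(Cn2cncc2-c2cc3cc(Br)ccc3[nH]2)cc1` gives 4290 nM in an assay on HEK293 cells for inhibition of Indoleamine 2,3-dioxygenase 1 (Homo sapiens), with a stated time of 30 min; on this read-out higher numbers stand for an effect only at larger amounts of compound and lower numbers for an effect already at smaller amounts. Compound 2 `Brc1ccc2[nH]c(-c3cncn3CC3CCCCN3)cc2c1` gives 10700 nM in this assay, and compound 3 `Nc1ccccc1Cn1cncc1-c1cc2cc(Br)ccc2[nH]1` gives 12000 nM. Among these three numbers compound 3 stands highest; its nearest neighbour is compound 2, the step of a 1.1-fold higher number from compound 2 to compound 3 (0.05 log units; within the scatter) lying within the scatter, while the step of a 2.8-fold higher number from compound 1 to compound 3 (0.45 log units; beyond the scatter) is beyond it.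

Compound 4 `Oc1cccc(Cn2cncc2-c2cc3cc(Br)ccc3[nH]2)c1` is obtained from compound 3 by the change (3-hydroxyphenyl in place of 2-aminophenyl on a saturated chain carbon bound to an aromatic nitrogen). Within the data shown here, no measured step swaps one substituted phenyl for another; the two steps that bear on it, a 2.8-fold higher number from compound 1 to compound 3 (0.45 log units; beyond the scatter) and a 2.5-fold higher number from compound 1 to compound 2 (0.40 log units; beyond the scatter), both exchange the whole group on that chain carbon and both are modest in size. Compound 4 keeps a six-membered aromatic ring with one donor and one acceptor, so only a modest step, in either direction, is expected in this assay.

Compound 4 is therefore expected to give about 8000 nM, with a likely range from 3000 nM to 25000 nM, which means an expected step of a 1.5-fold lower number from compound 3 to compound 4 (0.18 log units; within the scatter).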

Compound 4, half-maximal effective concentration: 9970 nM
Compound 4: the middle estimate sits 1.2-fold (0.10 log units) below what was measured, and the stated range covers the measured number.
By their numbers in this assay, from the lowest: compound 1; then compounds 4, 2 and 3 (each within the scatter of the next).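

In this assay, among these compounds, the exchange of 3-hydroxyphenyl for 2-aminophenyl on a saturated chain carbon bound to an aromatic nitrogen gives the first comparison of one substituted phenyl with another, and a 1.2-fold lower number from compound 3 to compound 4 (0.08 log units; within the scatter) lies within the scatter. The same holds for a 1.1-fold lower number from compound 2 to compound 4 (0.03 log units; within the scatter) so that compound 2, compound 3 and compound 4 cannot be told apart here, even though compound 2 carries piperidin-2-yl instead of a substituted phenyl. Only compound 1, with 4-methylphenyl, stands apart: a 2.3-fold higher number from compound 1 to compound 4 (0.37 log units; beyond the scatter) is beyond the scatter and modest, like a 2.5-fold higher number from compound 1 to compound 2 (0.40 log units; beyond the scatter) and a 2.8-fold higher number from compound 1 to compound 3 (0.45 log units; beyond the scatter) and no measurement offered here accounts for this grouping.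

The two substituted phenyl groups differ both in the group they carry and in its place on the ring, and neither 3-aminophenyl nor 2-hydroxyphenyl is among the compounds shown, so the amine and the hydroxyl remain unseparated. Also open, on these data alone, is how a carboxylic acid, a methoxy group or a longer chain carried on the phenyl ring would read at this position.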